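A few compounds are considered here, and "the series" means these few. Any claim that something is new, unique, unknown or untested is made for them only; others in the source may bear on it.

Measured so far:
compound 1 `O=C(NO)c1ccc(-c2cn([C@@H]3C[C@@H](C(=O)O)N(Cc4ccccc4)C3)nn2)cc1` — < 10%
compound 2 `O=C(/C=C/c1cn([C@H]2C[C@H](C(=O)O)N(Cc3ccccc3)C2)nn1)NO` — 14%
compound 3 `O=C(NO)c1ccc(-c2cn([C@H]3C[C@H](CO)N(Cc4ccccc4)C3)nn2)cc1` — 16%

Of the compounds shown here, three sharing the benzyl-substituted five-membered ring have been tested in an assay on Sf9 cells for inhibition of histone deacetylase 11 (Homo sapiens), read by fluorescence, tested at 0.5 uM; on this read-out lower numbers stand for less inhibition and higher numbers for more inhibition at the one concentration tested (going by the name of the read-out). For compound 1 the result is a limit of the assay rather than a number, as the limit of < 10% in this assay, at which 1 of the 3 values shown sits, records. Compound 2 gives 14% in this assay, and compound 3 gives 16%. Compound 3 and its nearest neighbour, compound 2, differ by an amount that lies within the scatter of repeated measurements, so the two cannot be ranked against each other.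

Compound 4 `O=C(NO)c1ccc(-c2cn([C@H]3C[C@H](C(=O)O)N(Cc4ccccc4)C3)nn2)cc1` has not yet been measured in this assay. It differs from compound 3 in one place: carboxy in place of hydroxymethyl on a saturated ring carbon. No step between two measured compounds describes this kind of exchange, so nothing shown tells how the change should play out. Given that all three numbers so far sit at or near the bottom of the scale, the step from compound 3 to compound 4 in this assay is expected to be small, and in either direction it is not expected to exceed the scatter: a number 4 percentage points lower from compound 3 to compound 4 (within the scatter). Compound 4 is accordingly estimated at 12% in this assay, with a range from 4% to 22%.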

Compound 4, a percentage reported as inhibition, at one concentration (the size of the read-out at that concentration, not a potency): < 10%
Compound 4 gave a limit, no number; the forecaster's own chance of this, stated with the estimate: 30%; at least 2 percentage points between middle value and limit.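

In this assay, carboxy in place of hydroxymethyl on the saturated ring carbon gives a number at least 6 percentage points lower from compound 3 to compound 4 (that floor lies within the scatter), and 4-(hydroxycarbamoyl)phenyl in place of 2-(hydroxycarbamoyl)ethenyl on the aromatic carbon gives a number at least 4 percentage points lower from compound 2 to compound 4 (that floor lies within the scatter). Compound 4 sits at a limit of the assay, so each of these steps is only a floor, and neither floor can be told from the scatter; at this position, the exchange of hydroxymethyl for carboxy therefore gives no sign of lifting the read-out off the bottom of the scale. The result also adds a pair that the earlier compounds did not offer, but the step between its two members cannot be read, and inverting both stereocentres shows no readable difference here, as both members rest on the same limit: the limit of < 10% in this assay, at which 2 of the 4 values shown sit.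

As far as these compounds go, whether the mirror-image forms truly differ in this assay stays open, since the only thing separating them is this: the fact that compounds 1 and 4 differ only in the configuration as drawn It also stays open whether an amine, a primary amide or a longer chain bearing a hydroxyl on the same saturated ring carbon would move the read-out clear of these low values.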